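The compounds below may be only part of what the source reports. "The series", "measured", "known", "first", "only" and "open" are said of these compounds alone.

Compound 1 `CC(C)n1cnc2ncnc(N)c21` is the point from which this step is taken. In an assay on CHO cells for displacement of a labelled ligand from adenosine receptor A3 (Homo sapiens) (a lower number here means a stronger inhibitor, a higher number a weaker inhibitor), compound 1 gives only a limit, > 100000 nM, so its true potency is not pinned to a number; this is the limit of > 100000 nM in this assay, at which 1 of the 2 values shown sits. Among the compounds with values here, compound 2 `Nc1ncnc2c1ncn2C1CCC1` carries a cyclobutyl on the same ring nitrogen, and in this assay compound 2 gives 33000 nM, which is the only actual number in the set. Compound 3 `Nc1ncnc2ncn(CCCO)c12` has not yet been tested in this assay. It differs from compound 1 by 3-hydroxypropyl in place of isopropyl on an aromatic nitrogen; in plain words, a 3-hydroxypropyl replaces the isopropyl on the aromatic nitrogen. Within the data shown here, no measured pair shows what such an exchange does here, and compound 1 itself offers only a limit, so the direction of the step is open. Given how weak compound 1 is, compound 3 is expected to remain weak, with an estimated 80000 nM in this assay, spanning 15000 nM to 300000 nM. The expected step is an at least 1.2-fold lower number from compound 1 to compound 3 (0.09 log units; that floor lies within the scatter).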

Compound 3, inhibition constant: > 100000 nM
Compound 3: no number, only a limit (the forecaster's own chance of this, stated with the estimate: 60%); middle value at least 1.2-fold (0.09 log units) away from the limit.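

In this assay, within the data shown here, compound 1 and compound 3 each give only a limit, so no step between them can be read: the limit of > 100000 nM in this assay, at which 2 of the 3 values shown sit. The compounds shown leave open whether 3-hydroxypropyl in place of isopropyl on the aromatic nitrogen changes the true potency at all.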